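The source may hold more compounds than are shown below. What is called first, only, known or untested is meant among the compounds shown, and "the series" means these compounds.

Compound 1 `CCCOc1ccccc1C1CC(=O)c2ccccc2O1` and compound 2 `CCCCOc1ccccc1C1CC(=O)c2ccccc2O1` share one core and differ only in the length of the chain attached through an oxygen on the aromatic ring. In a functional assay on J774.A1 cells (Mus musculus) for inhibition, read by immunoassay, with a stated time of 12 h, tested at 30 uM (on this read-out higher numbers stand for more inhibition at the one concentration tested (going by the name of the read-out) and lower numbers for less inhibition), compound 1 gives 43.6%, and in the same test compound 2 gives 42.5%. The step of a number 1.1 percentage points lower from compound 1 to compound 2 (within the scatter) shows that adding a carbon to that chain left the read-out unchanged for practical purposes, so compound 2 stands at the same level as compound 1 on the numbers at hand.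

Compound 3 `O=C1CC(c2ccccc2OCc2ccccc2)Oc2ccccc21` carries a larger change at the same chain: phenyl in place of propyl on a saturated chain carbon bound to an oxygen on an aromatic ring. Going by the values given here, the only measured step is the one from compound 1 to compound 2, and it was within the scatter, which says that a small extension of this chain made no difference; it does not directly cover the arrival of an aromatic ring. With nothing pointing in either direction, the expectation for the step of a number 0.5 percentage points lower from compound 2 to compound 3 (within the scatter) is one that stays within the scatter. Compound 3 is therefore estimated at 42%, with a plausible range from 25% to 60%.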

Compound 3, a percentage reported as inhibition, at one concentration (the size of the read-out at that concentration, not a potency): 91.5%
The estimate for compound 3 lay 49.5 percentage points below the measured number, outside the stated range (above it).
By their numbers in this assay, from the lowest: compounds 2 and 1 (each within the scatter of the next); then compound 3.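

At the saturated chain carbon bound to an oxygen on an aromatic ring, this assay turns out to be highly sensitive to what is attached: phenyl in place of propyl gives a number 49 percentage points higher from compound 2 to compound 3 (beyond the scatter) in this series, and phenyl in place of ethyl gives a number 47.9 percentage points higher from compound 1 to compound 3 (beyond the scatter) on the same read-out. The two plain chains had suggested that this part of the molecule hardly mattered, but that held only for a one-carbon extension, and the change from butoxy to benzyloxy shows that this position can carry a large difference in inhibition at the one concentration tested. Nothing available explains why this aromatic ring is accompanied by such a rise.

The compounds shown cannot separate the effect of the aromatic ring from that of a ring in general, a question that cyclohexyl in place of phenyl would address. They also leave open how a longer chain such as hexyl would compare, and whether a phenyl ring bearing a methoxy group or a chlorine atom, or a pyridine ring in its place, would keep the higher number.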